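Same Ring Swap Tried on a Second Core

A few compounds are considered here, and "the series" means these few. Any claim that something is new, unique, unknown or untested is made for them only; others in the source may bear on it.

Three compounds have been measured in a functional assay on MV4-11 cells (Homo sapiens) for antiproliferative activity, read by resazurin assay, with a stated time of 72 h; on this read-out higher numbers stand for weaker inhibition of growth and lower numbers for stronger inhibition of growth:

Compound 1 `CC(=O)N1CCN(c2ccc(Nc3nccc(-c4c[nH]c5cccnc45)n3)cc2)CC1` gives 420 nM.
Compound 2 `CC(=O)N1CCCN(c2cccc(Nc3nccc(-c4c[nH]c5cccnc45)n3)c2)CC1` gives 688 nM.
Compound 3 `CC(=O)N1CCN(c2ccc(Nc3nccc(-c4n[nH]c5ccccc45)n3)cc2)CC1` gives 346 nM.

Compound 3 differs from compound 1 by a group of 9 heavy atoms (7 carbon, 2 nitrogen; one five-membered aromatic ring with 2 hetero atoms, one six-membered aromatic ring of carbon only) in place of a group of 9 heavy atoms (7 carbon, 2 nitrogen; one five-membered aromatic ring with 1 hetero atom, one six-membered aromatic ring with 1 hetero atom), on an aromatic carbon. That step moved the read-out by a 1.2-fold lower number from compound 1 to compound 3 (0.08 log units; within the scatter), so on the core of compound 1 the exchange left the growth inhibition essentially where it was. Compound 2 carries a different core; how its core differs from that of compound 1 is not broken down here, and its value sits within the scatter of both compound 1 and compound 3, so no order among the three can be drawn.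

Compound 4 `CC(=O)N1CCCN(c2cccc(Nc3nccc(-c4n[nH]c5ccccc45)n3)c2)CC1` has not yet been measured. It stands to compound 2 as compound 3 stands to compound 1: the difference is a group of 9 heavy atoms (7 carbon, 2 nitrogen; one five-membered aromatic ring with 2 hetero atoms, one six-membered aromatic ring of carbon only) in place of a group of 9 heavy atoms (7 carbon, 2 nitrogen; one five-membered aromatic ring with 1 hetero atom, one six-membered aromatic ring with 1 hetero atom), on an aromatic carbon, and the place of the exchange is described in the same words in both pairs, so this is the same change on a second core.

Since the step from compound 1 to compound 3 in this assay was a 1.2-fold lower number from compound 1 to compound 3 (0.08 log units; within the scatter), a step of similar size is expected here, namely a 1.2-fold lower number from compound 2 to compound 4 (0.08 log units; within the scatter). Compound 4 is therefore estimated to give 570 nM in this assay, most likely between 250 nM and 1300 nM. This expectation rests on a single measured pair, so its footing is narrow.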

Compound 4, concentration for 50% growth inhibition: 18 nM
Compound 4: middle estimate off by 32-fold (1.50 log units), on the high side; measured number outside the range, below it.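

In this assay, the entry of 1H-indazol-3-yl on the second core gave a 38-fold lower number from compound 2 to compound 4 (1.58 log units; beyond the scatter), which is a large step where the same exchange on the first core had barely registered. Set side by side, the two results show that the exchange did not carry over from one core to the other with the same size: the same change on two cores in this assay, a 1.2-fold lower number (0.08 log units; within the scatter) from compound 1 to compound 3 and a 38-fold lower number (1.58 log units; beyond the scatter) from compound 2 to compound 4, 31-fold (1.50 log units) apart, beyond the scatter of two such steps This shows that, in this series, a step read on one core cannot simply be transferred to another, but it does not show which feature of the core is responsible, as the difference between the cores of compound 1 and compound 2 is not broken down into single changes, and two pairs give no rule for any further core.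

Still open, on these data alone, is how the exchange behaves on a core that carries only part of the difference between compound 1 and compound 2. Also open, as far as these compounds go, is whether the large step on the core of compound 2 persists when the acetyl group shared by all four compounds is replaced by a free amine, a carboxylic acid or a longer chain.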